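The compounds below may be only part of what the source reports. "The series", "measured", "known", "first", "only" and "open" are said of these compounds alone.

Compound 1 `CCOC(=O)c1cc(-c2cccc(OCc3cccc(C)c3)c2)on1`, compound 2 `CCOC(=O)c1cc(-c2cccc(OCc3ccccc3Cl)c2)on1` and compound 3 `CCOC(=O)c1cc(-c2cccc(OCc3ccccc3F)c2)on1` share one core and differ only in the group on a saturated chain carbon bound to an oxygen on an aromatic ring. In an ADME assay on Vero cells (Chlorocebus sabaeus) for cytotoxicity, with a stated time of 72 h (a higher number here means a weaker inhibitor, a lower number a stronger inhibitor), compound 1 gives > 128000 nM, a limit of the assay. In this assay compound 2 gives > 128000 nM, also a limit. The step that the two limits leave unreadable from compound 1 to compound 2 thus has no readable size. For compound 3 the entry in this assay reads "not determined" (no result reported), so compound 3 has no number of its own, and its two neighbours both sit at the limit of > 128000 nM in this assay, at which 2 of the 3 values shown sit. Compound 4 `CCOC(=O)c1cc(-c2cccc(OCc3cccc(F)c3F)c2)on1` differs from compound 3 by fluoro in place of hydrogen on an aromatic carbon. Going by the values given here, no measured step gives a readable size for this change, so no direction beyond the scatter is expected in this assay, and a limit is the likelier outcome. Compound 4 is expected to give about 128000 nM, within 64000 nM to 256000 nM.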

Compound 4, half-maximal inhibitory concentration: > 128000 nM
Compound 4 was reported as a limit; the forecaster's own chance of this, stated with the estimate: 85%; the middle value lies on the limit itself.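

In this assay, going by these compounds alone, compound 1, compound 2 and compound 4 are all reported as limits, so no step among them can be read. For this assay the compounds shown leave open where any of them would reach half-maximal inhibition, and whether changing this group matters at all.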